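The source may hold more compounds than are shown below. What is called first, only, known or untested is meant among the compounds shown, and "the series" means these compounds.

Series notes. Compound 1 `Nc1ccccc1NC(=O)c1ccc(CNCc2nc(-c3ccc(C(F)(F)F)cc3)no2)cc1` and compound 2 `Nc1ccccc1NC(=O)c1ccc(CNCc2nc(-c3ccc(Cl)cc3)no2)cc1` share one core and differ only in the substituent on an aromatic carbon. Going by the values given here, in a functional assay on U-937 cells (Homo sapiens) for inhibition, read by MTT assay, with a stated time of 72 h (on this read-out higher numbers stand for weaker inhibition and lower numbers for stronger inhibition), compound 1 gives 2580 nM, the highest of the two numbers so far; compound 2 gives 430 nM. Among the compounds with values here, the one measured step is a 6.0-fold lower number from compound 1 to compound 2 (0.78 log units; beyond the scatter), and it alters a group remote from the amide. Compound 3 `O=C(NO)c1ccc(CNCc2nc(-c3ccc(C(F)(F)F)cc3)no2)cc1` is not yet measured. It differs from compound 1 by hydroxy in place of 2-aminophenyl on an amide-type nitrogen. Within the data shown here, no measured step touches this amide-type nitrogen, so the single chloro-for-trifluoromethyl step gives no direct read on the size or direction of the present change in this assay; the expectation therefore rests on the change itself and is held wide. Compound 3 is expected at 500 nM, within 50 nM to 5000 nM. The expected step is a 5.2-fold lower number from compound 1 to compound 3 (0.71 log units; beyond the scatter), with a result within the scatter of compound 1 not excluded.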

Compound 3, half-maximal inhibitory concentration: 8050 nM
Beside the measured number, compound 3's estimate is 16-fold (1.21 log units) below it; measured number outside the range, above it.
By their numbers in this assay, from the lowest: compound 2; then compound 1; then compound 3.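

In this assay, the amide-type nitrogen now has its first measured step: hydroxy in place of 2-aminophenyl gives a 3.1-fold higher number from compound 1 to compound 3 (0.49 log units; beyond the scatter) on the trifluoromethyl-bearing core. This step lies beyond the scatter, so the group on this nitrogen, and not only the remote aromatic substituent, changes the read-out, and among these two compounds the 2-aminophenyl form has the lower number. The data shown offer nothing that explains this step.

From the compounds shown here alone, it remains open whether the same order between 2-aminophenyl and hydroxy holds when chloro replaces trifluoromethyl, as in compound 2. A plain phenyl on this nitrogen would also be needed to separate the contribution of the ring from that of its amine.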